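Urea substituent variation on the shared quinazoline-free core

The compounds below may be only part of what the source reports. "The series", "measured", "known", "first", "only" and "open" are said of these compounds alone.

Measured so far in a functional assay on A-431 cells (Homo sapiens) for antiproliferative activity, read by sulforhodamine B assay, with a stated time of 72 h; a lower number here means a stronger inhibitor, a higher number a weaker inhibitor:
- compound 1 `CN(C)CCNC(=O)Nc1cc2c(Nc3ccc(F)c(Cl)c3)ncnc2cc1O[C@H]1CCOC1`: 806 nM
- compound 2 `CN1CCN(C(=O)Nc2cc3c(Nc4ccc(F)c(Cl)c4)ncnc3cc2O[C@H]2CCOC2)CC1`: 675 nM
- compound 3 `O=C(Nc1cc2c(Nc3ccc(F)c(Cl)c3)ncnc2cc1O[C@H]1CCOC1)N1CCC(F)(F)CC1`: 1860 nM

Compound 3 gives the highest number of the three. Its distance from compound 1 is a 2.3-fold higher number from compound 1 to compound 3 (0.36 log units; beyond the scatter) and from compound 2 is a 2.8-fold higher number from compound 2 to compound 3 (0.44 log units; beyond the scatter); both steps are beyond the scatter, so compound 3 is the weakest of the measured set. Compound 1 and compound 2 sit within the scatter of each other, shown by a 1.2-fold lower number from compound 1 to compound 2 (0.08 log units; within the scatter).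

Compound 4 `O=C(Nc1cc2c(Nc3ccc(F)c(Cl)c3)ncnc2cc1O[C@H]1CCOC1)N1CCC(N2CCCC2)CC1` is the next member. The change from compound 3 is 4-(pyrrolidin-1-yl)piperidin-1-yl in place of 4,4-difluoropiperidin-1-yl on a carbonyl carbon. The entering group brings one hydrogen-bond acceptor, which the leaving group lacked; compounds 1 and 2 likewise carry a further nitrogen in the group on the carbonyl carbon, and both gave lower numbers than compound 3. For the measured compounds named here, the steps that bear on this are a 2.3-fold higher number from compound 1 to compound 3 (0.36 log units; beyond the scatter) and a 2.8-fold higher number from compound 2 to compound 3 (0.44 log units; beyond the scatter), each modest and beyond the scatter. Reversing that direction is therefore expected here: compound 4 is estimated to move by a 2.5-fold lower number from compound 3 to compound 4 (0.39 log units; beyond the scatter) in this assay. On that basis compound 4 is expected to give about 750 nM, with a range from 300 nM to 1900 nM.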

Compound 4, half-maximal inhibitory concentration: 317 nM
Compound 4: middle estimate off by 2.4-fold (0.37 log units), on the high side; the measured number falls inside the stated range.
By their numbers in this assay, from the lowest: compound 4; then compounds 2 and 1 (each within the scatter of the next); then compound 3.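

In this assay, compound 4 is the strongest of the four, and its group on the carbonyl carbon separates from both earlier nitrogen-bearing groups (a 2.1-fold lower number from compound 2 to compound 4 (0.33 log units; beyond the scatter); a 2.5-fold lower number from compound 1 to compound 4 (0.41 log units; beyond the scatter)), a separation not seen between compound 1 and compound 2, which sit within the scatter of each other. With a 5.9-fold lower number from compound 3 to compound 4 (0.77 log units; beyond the scatter) also beyond the scatter, the three compounds with a further nitrogen in this group all give lower numbers than compound 3, yet they do not form a single level, so the presence of that nitrogen does not alone describe the results at this position. The data give no measured reason for the lower number of compound 4 or for the differences among these groups.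

The compounds shown do not separate the contribution of the pyrrolidine ring from that of the piperidine ring that carries it, a question that 4-(dimethylamino)piperidin-1-yl or 4-(morpholin-4-yl)piperidin-1-yl on the same carbonyl carbon would address. Unsubstituted piperidin-1-yl would also give a direct reference for both 4-substituted piperidine groups, compound 3 and compound 4.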